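The source may hold more compounds than are shown below. What is called first, only, known or untested is meant among the compounds shown, and "the series" means these compounds.

Compound 1, `CN1CCN(c2ccc(Nc3ncc4nc(Sc5ccccc5)n(C5CCOCC5)c4n3)cc2)CC1`, in an assay on isolated protein for inhibition of Receptor tyrosine-protein kinase erbB-3 variant L858R (Homo sapiens), read by luminescence and Kinase-Glo, with a stated time of 40 min; on this read-out higher numbers stand for weaker inhibition and lower numbers for stronger inhibition: compound 1 gives 2 nM.
Compound 2, `CN1CCN(c2ccc(Nc3ncc4nc(Sc5ccccc5)n(C5CCCC5)c4n3)cc2)CC1`, in this assay: compound 2 gives 4.2 nM.

Going by the values given here, compound 1 holds the lowest of the two numbers so far; the only step measured, a 2.1-fold higher number from compound 1 to compound 2 (0.32 log units; beyond the scatter), exchanges the group on the aromatic nitrogen of the shared core and is counted as beyond the scatter, though only modestly.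

Compound 3, `CN(C)C1CCN(c2ccc(Nc3ncc4nc(Sc5ccccc5)n(C5CCOCC5)c4n3)cc2)CC1`, is not yet measured. It differs from compound 1 at a different place, on an aromatic carbon of a six-membered aromatic ring of carbon only, para to a large group: 4-(dimethylamino)piperidin-1-yl in place of 4-methylpiperazin-1-yl on an aromatic carbon. Among the compounds with values here, no measured step touches that position, so the change from compound 1 to compound 3 has no direct precedent. Without a measured guide, the expectation is no change beyond the scatter in this assay, that is a 1.5-fold higher number from compound 1 to compound 3 (0.18 log units; within the scatter). Compound 3 is therefore estimated at 3 nM, in the range 1 nM to 9 nM.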

Compound 3, half-maximal inhibitory concentration: 1.9 nM
Compound 3: the middle estimate sits 1.6-fold (0.20 log units) above what was measured; the range from low to high includes it.
By their numbers in this assay, from the lowest: compounds 3 and 1 (each within the scatter of the next); then compound 2.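

In this assay, putting 4-(dimethylamino)piperidin-1-yl in place of 4-methylpiperazin-1-yl on the aromatic carbon para to a large group gives a 1.1-fold lower number from compound 1 to compound 3 (0.02 log units; within the scatter) and so opens a second position on the shared core to comparison. At this position, a larger group with one hetero atom in its ring rather than two leaves the reading of compound 3 within the scatter of compound 1, so the two groups cannot be told apart here. Nothing available explains why they read alike.

As far as these compounds go, it remains open whether a group with no ring at this position, such as a short chain ending in an amine or a carboxylic acid, would read the same. Also open, from the compounds shown here alone, is whether 4-(dimethylamino)piperidin-1-yl would behave alike with cyclopentyl on the aromatic nitrogen.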